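The source may report more compounds than this note shows. Statements on the series, on what has been measured and on what is new or still open speak of the compounds shown alone.

In a functional assay on MIA PaCa-2 cells (Homo sapiens) for inhibition, read by MTT assay, with a stated time of 7 days (a higher number here means a weaker inhibitor, a lower number a stronger inhibitor), compound 1 `CCCN(CCC)S(=O)(=O)c1ccc(S(=O)(=O)N2CCC[C@@H](C(=O)OCC)C2)cc1` gives 2300 nM, while compound 2 `CC(C)c1noc(N2CCN(C(=O)[C@@H]3CCCN(S(=O)(=O)c4ccc(S(=O)(=O)NC(C)(C)C)cc4)C3)CC2)n1` gives 300 nM, the lower of the two numbers and a gap beyond the scatter. Compound 3 `CCOC(=O)N1CCC[C@H](S(=O)(=O)c2ccc(S(=O)(=O)N(CC)CC)cc2)C1` is reported only as a limit, > 30000 nM. Compound 4 `CCN(CC)S(=O)(=O)c1ccc(S(=O)(=O)N2CCC[C@@H](C(=O)N3CCN(c4nc(C(C)C)no4)CC3)C2)cc1` remains unmeasured. It carries diethylamino in place of (tert-butyl)amino on a sulfonyl sulfur. Among the compounds with values here, no measured pair isolates this change, so the expectation starts from compound 2 at 300 nM, and it allows for a modest rise towards compound 1 at 2300 nM. The expected change is a moderate weakening, slightly beyond the scatter, with the estimated step of a 2.3-fold higher number from compound 2 to compound 4 (0.37 log units; beyond the scatter). For compound 4 the estimated value is 700 nM, with an expected range of 200 nM to 3000 nM.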

Compound 4, half-maximal inhibitory concentration: 50 nM
Compound 4: the middle estimate sits 14-fold (1.15 log units) above what was measured; measured number below the stated range.
By their numbers in this assay, from the lowest: compound 4; then compound 2; then compound 1. At a limit, above all of these: compound 3.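

In this assay, within the data shown here, diethylamino in place of (tert-butyl)amino on a sulfonyl sulfur gives the first comparison here that differs in one place: a 6.0-fold lower number from compound 2 to compound 4 (0.78 log units; beyond the scatter). The position therefore responds to this change, and the entering group, with no hydrogen-bond donor where the leaving group has one, goes with the lower number. Nothing shown gives a reason for this step. On these data alone, whether dimethylamino or a piperidine ring on the same sulfonyl sulfur would keep the lower number stays open. This single pair also cannot separate the lost donor from the different arrangement of the carbons.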